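A few compounds are considered here, and "the series" means these few. Any claim that something is new, unique, unknown or untested is made for them only; others in the source may bear on it.

Two measured compounds share one core. Compound 1 `COc1ccc(OC)c(-c2cc(-c3ccccc3)nn2-c2ccc(S(=O)(=O)NC(C)=O)cc2)c1` carries a 2,5-dimethoxyphenyl group, and in a functional assay on cells (Cancer cell lines, Homo sapiens) for cytotoxicity, read by sulforhodamine B assay, with a stated time of 48 h (on this read-out lower numbers stand for stronger inhibition of growth and higher numbers for weaker inhibition of growth), compound 1 gives 13300 nM. Compound 2 `CC(=O)NS(=O)(=O)c1ccc(-n2nc(-c3ccccc3)cc2-c2cc(O)ccc2O)cc1` carries a 2,5-dihydroxyphenyl group in its place, and in this assay compound 2 gives 78100 nM. Within the data shown here, the step of a 5.9-fold higher number from compound 1 to compound 2 (0.77 log units; beyond the scatter) sets compound 2 at the highest of the two numbers known here.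

Compound 3 `CC(=O)NS(=O)(=O)c1ccc(-n2nc(-c3ccccc3)cc2C2=CC(=O)C=CC2=O)cc1` differs from compound 2 by the change (a group of 8 heavy atoms (6 carbon, 2 oxygen; one six-membered non-aromatic ring of carbon only) in place of a group of 8 heavy atoms (6 carbon, 2 oxygen; one six-membered aromatic ring of carbon only), on an aromatic carbon). Among the measured compounds shown here, no measured step covers this exchange itself: the only step known, a 5.9-fold higher number from compound 1 to compound 2 (0.77 log units; beyond the scatter), concerns the same attachment point but a different pair of groups, so it tells only that the group at this place can move the read-out in this assay by a modest amount. On that thin basis, a step of similar size is expected, and since compound 2 stands at the weak end of what is known, the direction is expected to favour stronger growth inhibition, with the step of a 2.6-fold lower number from compound 2 to compound 3 (0.42 log units; beyond the scatter). Compound 3 is therefore estimated at 30000 nM in this assay, within a range from 8000 nM to 120000 nM.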

Compound 3, concentration for 50% growth inhibition: 90000 nM
Beside the measured number, compound 3's estimate is 3.0-fold (0.48 log units) below it; measured number inside the range.
By their numbers in this assay, from the lowest: compound 1; then compounds 2 and 3 (each within the scatter of the next).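

In this assay the exchange of the 2,5-dihydroxyphenyl group for the non-aromatic ring of carbon only gives a 1.2-fold higher number from compound 2 to compound 3 (0.06 log units; within the scatter) and so does not separate the two groups at this place, although the entering group has 0 hydrogen-bond donors where the leaving group has 2 hydrogen-bond donors and its ring is no longer aromatic. The 2,5-dimethoxyphenyl group now stands apart from both of the others, with a 6.8-fold higher number from compound 1 to compound 3 (0.83 log units; beyond the scatter) added to the earlier gap to compound 2, so among these three groups only the one in compound 1 goes with a lower number in this read-out. Nothing given here offers an explanation for this result.

The three compounds leave open how a plain phenyl, a phenyl with a single methoxy, or a phenyl with an amine or a carboxylic acid at this place would compare with the 2,5-dimethoxyphenyl group of compound 1. They also leave open whether a longer chain in place of the acetyl group on the sulfonamide, or another group in place of the phenyl group on the shared core, would shift these numbers.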